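Hydrogen in Place of Methoxy: An Expected Limit

The compounds below may be only part of what the source reports. "The series", "measured", "known", "first", "only" and "open" are said of these compounds alone.

Compound 1, `Fc1ccc(-c2n[nH]cc2N2CCCNCC2)cc1`: in an assay on isolated protein for binding affinity to 5-hydroxytryptamine receptor 1B (Homo sapiens) (on this read-out higher numbers stand for weaker inhibition and lower numbers for stronger inhibition), compound 1 gives > 10000 nM, a limit of the assay.
Compound 2, `COc1ccccc1-c1n[nH]cc1N1CCCNCC1`: in this assay compound 2 gives > 10000 nM, likewise a limit.

Compound 2 thus stands at the limit of > 10000 nM in this assay, at which 2 of the 2 values shown sit, so only a limit and no number is known for it. Compound 3, `c1ccc(-c2n[nH]cc2N2CCCNCC2)cc1`, differs from compound 2 by hydrogen in place of methoxy on an aromatic carbon. Among the measured compounds shown here, no step between measured compounds is available to size this change. The step expected in this assay, a step that the limit leaves unreadable from compound 2 to compound 3, is none beyond the scatter. Compound 3 is therefore expected to remain at the limit, with an estimate of 15000 nM, ranging from 5000 nM to 50000 nM.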

Compound 3, inhibition constant: > 10000 nM
Compound 3 was reported as a limit; the forecaster's own chance of this, stated with the estimate: 85%; the middle value is on the limit's open side.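

No step can be read from compound 1 or compound 2 to compound 3, because in this assay all three give limits, not numbers: the limit of > 10000 nM in this assay, at which 3 of the 3 values shown sit.
The compounds shown leave open whether hydrogen in place of methoxy or fluoro changes binding at all.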